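Pentyl for aryl on the triazole nitrogen

The source may hold more compounds than are shown below. What is called first, only, known or untested is meant among the compounds shown, and "the series" means these compounds.

Compound 2 `CC1(C)CCc2c(ccc(C(=O)/C=C/c3ccc(OCc4cn(-c5ccc(Cl)cc5)nn4)cc3)c2O)O1` carries a 4-chlorophenyl on the aromatic nitrogen; in a functional assay on A549 cells (Homo sapiens) for antiproliferative activity, read by MTT assay (on this read-out lower numbers stand for stronger inhibition and higher numbers for weaker inhibition), compound 2 gave "not active" (no number reported), a report without a single number. Compound 4 `CCCCCn1cc(COc2ccc(/C=C/C(=O)c3ccc4c(c3O)CCC(C)(C)O4)cc2)nn1` differs from it by pentyl in place of 4-chlorophenyl on an aromatic nitrogen. For the measured compounds named here, the one measured step of this kind runs from compound 1 `Cc1c(-n2cc(COc3ccc(/C=C/C(=O)c4cc5c(cc4O)OC(C)(C)CC5)cc3)nn2)cccc1[N+](=O)[O-]`, which in this assay gives 65900 nM, to compound 3 `CCCCCn1cc(COc2ccc(/C=C/C(=O)c3cc4c(cc3O)OC(C)(C)CC4)cc2)nn1`, which gives 91300 nM: a 1.4-fold higher number from compound 1 to compound 3 (0.14 log units; within the scatter). That swap left the read-out essentially unchanged. With no number for compound 2 to build on, the expectation for compound 4 rests on compounds 1 and 3 alone, and no direction beyond the scatter can be stated. Compound 4 is expected near 90000 nM, within 40000 nM to 200000 nM, with a real chance that again no number is obtained.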

Compound 4, half-maximal inhibitory concentration: 48600 nM
Beside the measured number, compound 4's estimate is 1.9-fold (0.27 log units) above it; the range from low to high includes it.
By their numbers in this assay, from the lowest: compounds 4, 1 and 3 (each within the scatter of the next).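

The step from compound 2 to compound 4 cannot be read: compound 2 has no single number. The compounds shown leave open how pentyl and 4-chlorophenyl compare on the core of compound 4. No evidence bears on this result.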